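Methylamino in place of chloro on a weak core

The source may report more compounds than this note shows. Statements on the series, on what has been measured and on what is new or still open speak of the compounds shown alone.

In a functional assay on KB cells (Homo sapiens) for inhibition (on this read-out higher numbers stand for weaker inhibition and lower numbers for stronger inhibition), compound 1 `OCCOCn1c(Cl)nc2c(Cl)c(Cl)ccc21` shows only a limit, > 100000 nM, and no number beyond it. Compound 2 `OCCOCn1c(SCc2ccccc2)nc2cc(Cl)c(Cl)cc21` gives 55000 nM in this assay. For the measured compounds named here, the single value of compound 1 thus sits at the limit of > 100000 nM in this assay, at which 1 of the 2 values shown sits. Compound 3 `CNc1nc2c(Cl)c(Cl)ccc2n1COCCO` differs from compound 1 by methylamino in place of chloro on an aromatic carbon. Going by the values given here, no measured pair shows this change. Starting from the limit of compound 1, the step of a number no higher from compound 1 to compound 3 (the limit leaves the size open) is expected to be none beyond the scatter. Compound 3 is therefore estimated at 100000 nM, between 30000 nM and 300000 nM.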

Compound 3, half-maximal inhibitory concentration: > 100000 nM
Compound 3: no number, only a limit; the forecaster's own chance of this, stated with the estimate: 60%; the middle value sits exactly at the limit.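

No step from compound 1 to compound 3 can be read, since each gives only a limit and no number: the limit of > 100000 nM in this assay, at which 2 of the 3 values shown sit.

From the compounds shown here alone, whether methylamino in place of chloro on an aromatic carbon changes inhibition at all remains open.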